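Swapping the amide-side pyridine in a quinolinyl pyrazole series

A few compounds are considered here, and "the series" means these few. Any claim that something is new, unique, unknown or untested is made for them only; others in the source may bear on it.

Compound 1 `Cc1ccc(-c2cc(C(=O)Nc3ccc(Cl)nc3Cl)nn2-c2ccc3ccccc3n2)cc1`: 14000 nM
Compound 2 `Cc1ccc(-c2cc(C(=O)NCc3cccnc3)nn2-c2ccc3ccccc3n2)cc1`: 14100 nM
Compound 3 `Cc1ccc(-c2cc(C(=O)Nc3ccnc(Cl)c3)nn2-c2ccc3ccccc3n2)cc1`: 1600 nM

Of the three compounds measured in a functional assay on Huh-7 cells (Homo sapiens) for cytotoxicity, read by sulforhodamine B assay, with a stated time of 72 h (on this read-out higher numbers stand for weaker inhibition and lower numbers for stronger inhibition), compound 3 gives the lowest number, 1600 nM. Its nearest neighbour is compound 1 with 14000 nM, and compound 2 with 14100 nM stands furthest away, though both gaps are of about the same size and both lie beyond the scatter. Compound 1 and compound 2 are indistinguishable on these numbers, a 1.0-fold higher number from compound 1 to compound 2 (0.00 log units; within the scatter).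

Compound 4 `Cc1ccc(-c2cc(C(=O)Nc3ncc(Br)cc3Br)nn2-c2ccc3ccccc3n2)cc1` differs from compound 3 only on the amide-type nitrogen, where (3,5-dibromopyridin-2-yl in place of 2-chloropyridin-4-yl on an amide-type nitrogen). Among the measured compounds shown here, the steps that bear on this change are those that led to compound 3: an 8.8-fold lower number from compound 1 to compound 3 (0.94 log units; beyond the scatter) and an 8.8-fold lower number from compound 2 to compound 3 (0.95 log units; beyond the scatter). Both show that the group on the amide-type nitrogen moves the number by a modest amount, and compound 1, which also carries a pyridinyl with two halogens on that nitrogen, sits at the higher end. Compound 4 is therefore expected to move back toward compound 1, giving a 5.0-fold higher number from compound 3 to compound 4 (0.70 log units; beyond the scatter). The estimated value for compound 4 is 8000 nM, within a range from 2500 nM to 25000 nM.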

Compound 4, half-maximal inhibitory concentration: 11500 nM
Estimate against measurement, compound 4: 1.4-fold (0.16 log units) below, within the range that was stated.
By their numbers in this assay, from the lowest: compound 3; then compounds 4, 1 and 2 (each within the scatter of the next).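

In this assay the 3,5-dibromopyridin-2-yl group does not keep the low number of compound 3 (a 7.2-fold higher number from compound 3 to compound 4 (0.86 log units; beyond the scatter)), so the step shows that a halogenated pyridinyl ring on the amide-type nitrogen is not enough on its own to hold that level. Compound 4 instead joins the two other compounds, with no separation from the (pyridin-3-yl)methyl group (a 1.2-fold lower number from compound 2 to compound 4 (0.09 log units; within the scatter)) or from the 2,6-dichloropyridin-3-yl group (a 1.2-fold lower number from compound 1 to compound 4 (0.09 log units; within the scatter)). Three different groups at this place therefore give numbers within the scatter of one another, and among the four compounds only compound 3, with its 2-chloropyridin-4-yl group, stands apart.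

On these data alone, the step from compound 3 to compound 4 changes the halogen, the number of halogen atoms and the pattern of the ring in one move, so these compounds cannot say which of these changes matters, and whether a 2-bromopyridin-4-yl or a plain pyridin-4-yl group on the amide-type nitrogen would stay with compound 3 remains open. Nothing available here accounts for the separate place of compound 3.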